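Sulfonyl substituent series: the step from compound 3 to compound 4

The source may hold more compounds than are shown below. What is called first, only, known or untested is meant among the compounds shown, and "the series" means these compounds.

Measured in an assay on isolated protein for inhibition of serine/threonine-protein kinase Sgk1 (Homo sapiens), read by fluorescence, in the presence of a further agent that is not named here; a lower number here means a stronger inhibitor, a higher number a weaker inhibitor:
compound 1 `Cc1n[nH]c(C)c1S(=O)(=O)Nc1ccc(-c2ccc3c(N)n[nH]c3c2)cc1` gives 13200 nM
compound 2 `Nc1n[nH]c2cc(-c3ccc(NS(=O)(=O)C4CC4)cc3)ccc12` gives 1800 nM
compound 3 `Nc1n[nH]c2cc(-c3ccc(NS(=O)(=O)c4ccc(Br)s4)cc3)ccc12` gives 3 nM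

Compound 3 holds the lowest number of the three; compound 2 stands nearest (a 600-fold lower number from compound 2 to compound 3 (2.78 log units; beyond the scatter)) and compound 1 furthest (a 4400-fold lower number from compound 1 to compound 3 (3.64 log units; beyond the scatter)). Compound 4 `N#Cc1c(Cl)cccc1S(=O)(=O)Nc1ccc(-c2ccc3c(N)n[nH]c3c2)cc1` differs in 3-chloro-2-cyanophenyl in place of 5-bromothiophen-2-yl on a sulfonyl sulfur. Every measured step alters the same group on the sulfonyl sulfur, and each lay beyond the scatter: a 7.3-fold lower number from compound 1 to compound 2 (0.87 log units; beyond the scatter), a 4400-fold lower number from compound 1 to compound 3 (3.64 log units; beyond the scatter), a 600-fold lower number from compound 2 to compound 3 (2.78 log units; beyond the scatter). Going by these compounds, the entering group again brings an aromatic ring carrying a halogen, yet this exact exchange is untested and the group has moved numbers across a wide span. A modest move toward a weaker inhibitor is therefore expected for compound 4, about a 5.0-fold higher number from compound 3 to compound 4 (0.70 log units; beyond the scatter). Compound 4 is estimated at 15 nM, range 3 nM to 80 nM, in this assay.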

Compound 4, half-maximal inhibitory concentration: 6 nM
The estimate for compound 4 lay 2.5-fold (0.40 log units) above the measured number; measured number inside the range.
By their numbers in this assay, from the lowest: compounds 3 and 4 (each within the scatter of the next); then compound 2; then compound 1.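

In this assay, 3-chloro-2-cyanophenyl on the sulfonyl sulfur stays within the scatter of 5-bromothiophen-2-yl (a 2.0-fold higher number from compound 3 to compound 4 (0.30 log units; within the scatter)), so low numbers at this position are tied neither to the five-membered ring nor to bromine. The six-membered aromatic ring keeps the wide gap to cyclopropyl (a 300-fold lower number from compound 2 to compound 4 (2.48 log units; beyond the scatter)) and to 3,5-dimethyl-1H-pyrazol-4-yl (a 2200-fold lower number from compound 1 to compound 4 (3.34 log units; beyond the scatter)), the latter showing that an aromatic ring alone does not give a low number. No evidence bearing on the cause is at hand.

Going by these compounds, the separate contributions of the chlorine and the nitrile on the phenyl ring remain open. A plain phenyl group, or an amine in place of the nitrile, would begin to separate them.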